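The source may report more compounds than this note shows. Statements on the series, on what has been measured and on what is new or still open speak of the compounds shown alone.

Compound 2 `O=C(O)c1ccccc1-c1ccccc1C(=O)NCCCCCCCn1cc(-c2cccnc2)nn1` gives 38.5 nM in an assay for inhibition of Nicotinamide phosphoribosyltransferase (Mus musculus), read by fluorescence, with a stated time of 1 h, in the presence of a further agent that is not named here; a lower number here means a stronger inhibitor, a higher number a weaker inhibitor. Compound 1 `O=C(NCCCCCCCn1cc(-c2ccc[n+]([O-])c2)nn1)c1ccccc1-c1ccccc1` reaches only a limit of this assay, > 500 nM. Compound 3 `O=C(O)c1ccc(-c2ccccc2C(=O)NCCCCCCCn2cc(-c3cccnc3)nn2)cc1` likewise gives only a limit in this assay, > 500 nM. Compound 3 therefore stands at the weak end of the values shown, at the limit of > 500 nM in this assay, at which 2 of the 3 values shown sit, rather than at a measured number. Among the measured compounds shown here, the one step that reaches compound 3 is an at least 12-fold higher number from compound 2 to compound 3 (1.11 log units; beyond the scatter), a large step beyond the scatter. Compound 4 `O=C(NCCCCCCCn1cc(-c2cccnc2)nn1)c1ccccc1-c1c[nH]nn1` differs from compound 3 by 1H-1,2,3-triazol-4-yl in place of 4-carboxyphenyl on an aromatic carbon. For the measured compounds named here, no measured step covers this change directly; the step from compound 2 to compound 3 shows only that moving the carboxylic acid is costly, and compound 1, which carries no acid, also stops at the limit. A step of an at least 1.6-fold lower number from compound 3 to compound 4 (0.22 log units; that floor lies within the scatter) is expected in this assay, with no firm direction beyond the scatter. Compound 4 is expected to give about 300 nM in this assay, within 60 nM to 1500 nM, with a real chance that only a limit is reported.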

Compound 4, half-maximal inhibitory concentration: 42.5 nM
Beside the measured number, compound 4's estimate is 7.1-fold (0.85 log units) above it; the whole stated range lies above it.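

Among the compounds shown here, until now, the only step at this aromatic carbon, ortho to a large group, concerned where a carboxylic acid sat on the phenyl ring there. In this assay the change to 1H-1,2,3-triazol-4-yl gives an at least 11-fold lower number from compound 3 to compound 4 (1.07 log units; beyond the scatter) and so shows that a group without a carboxylic acid can serve at this position. The second step is a 1.1-fold higher number from compound 2 to compound 4 (0.04 log units; within the scatter) and lies within the scatter, so 1H-1,2,3-triazol-4-yl and 2-carboxyphenyl cannot be told apart here, while the weak end still rests on a limit and not a number: the limit of > 500 nM in this assay, at which 2 of the 4 values shown sit.

On these data alone, whether a tetrazole or a carboxylic acid set directly on this aromatic carbon would give a comparable number stays open. So does the effect of a methyl group on the triazole nitrogen or of a shorter chain.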